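Anilino variation in a triazolylmethylthio series: fluorophenyl analogue

The source may report more compounds than this note shows. Statements on the series, on what has been measured and on what is new or still open speak of the compounds shown alone.

Compound 1, `N#Cc1c(Nc2ccccc2Cl)nc(SCc2cn(Cc3ccccc3Cl)nn2)nc1-c1ccccc1`, in a functional assay on ECa-109 cells (Homo sapiens) for inhibition, read by MTT assay, with a stated time of 72 h (a higher number here means a weaker inhibitor, a lower number a stronger inhibitor), gives 28500 nM
Compound 2, `N#Cc1c(Nc2ccc(Cl)cc2)nc(SCc2cn(Cc3ccccc3Cl)nn2)nc1-c1ccccc1`, in this assay gives 1420 nM
Compound 3, `Cc1cccc(Nc2nc(SCc3cn(Cc4ccccc4Cl)nn3)nc(-c3ccccc3)c2C#N)c1`, in this assay gives 15600 nM

Compound 3 stands second highest of the three numbers. Its nearest neighbour is compound 1, the step of a 1.8-fold lower number from compound 1 to compound 3 (0.26 log units; within the scatter) lying within the scatter, while the step of an 11-fold higher number from compound 2 to compound 3 (1.04 log units; beyond the scatter) is the large one of the set.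

Compound 4, `N#Cc1c(Nc2ccccc2F)nc(SCc2cn(Cc3ccccc3Cl)nn2)nc1-c1ccccc1`, differs from compound 3 by 2-fluorophenyl in place of 3-methylphenyl on a nitrogen on an aromatic ring. Among the measured compounds shown here, two measured steps bear on this. The step of a 1.8-fold lower number from compound 1 to compound 3 (0.26 log units; within the scatter) shows that exchanging 2-chlorophenyl for 3-methylphenyl hardly moved the number, and the step of a 20-fold lower number from compound 1 to compound 2 (1.30 log units; beyond the scatter) shows that only 4-chlorophenyl set itself apart. For the measured compounds named here, compound 4 carries a 2-fluorophenyl where compound 1 carries a 2-chlorophenyl, so the value of compound 1 is the closer reference; no measured step covers 2-fluorophenyl itself.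

For compound 4 a step of a 1.3-fold higher number from compound 3 to compound 4 (0.11 log units; within the scatter) is expected, back toward the number of compound 1 and within the scatter. The estimate for compound 4 is 20000 nM, with a range of 7000 nM to 60000 nM.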

Compound 4, half-maximal inhibitory concentration: 23000 nM
Estimate against measurement, compound 4: 1.2-fold (0.06 log units) below; measured number inside the range.
By their numbers in this assay, from the lowest: compound 2; then compounds 3, 4 and 1 (each within the scatter of the next).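

In this assay, among the compounds shown here, fluoro in place of chloro on an aromatic carbon gives a 1.2-fold lower number from compound 1 to compound 4 (0.09 log units; within the scatter) and so stays within the scatter, the first direct halogen exchange. 2-Fluorophenyl in place of 3-methylphenyl gives a 1.5-fold higher number from compound 3 to compound 4 (0.17 log units; within the scatter) and also stays within the scatter, so compounds 1, 3 and 4 form one group by their numbers. For the compounds shown here, with a 16-fold higher number from compound 2 to compound 4 (1.21 log units; beyond the scatter) as a large step, 4-chlorophenyl remains the only group here set apart from the others. Nothing available explains these steps.

Still open, from the compounds shown here alone, is whether that gap follows the chloro itself or would also appear with 4-fluorophenyl or 4-methylphenyl. The response of this position to a phenyl ring carrying an amine or a carboxylic acid is also unknown.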